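The compounds below may be only part of what the source reports. "The series", "measured", "known", "first", "only" and "open" are said of these compounds alone.

Measured compounds so far:
compound 1 `CC[C@@H]1C(=O)N(C)c2cnc(-n3ccc4cc(F)ccc43)nc2N1C1CCCC1` gives "not active" (no number reported) in a functional assay on MCF7 cells (Homo sapiens) for antiproliferative activity, read by CCK-8 assay, with a stated time of 72 h (a lower number here means a stronger inhibitor of growth, a higher number a weaker inhibitor of growth), with no number reported;
compound 2 `CCC1C(=O)N(C)c2cnc(-n3ccc4cc(C(N)=O)ccc43)nc2N1c1ccn(C)n1` also gives "not active" (no number reported) in this assay, with no number reported;
compound 3 `CC[C@@H]1C(=O)N(C)c2cnc(Nc3ccc(S(N)(=O)=O)cc3)nc2N1C1CCCC1` gives 394 nM in this assay.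

Compound 1 therefore stands without a single number, and it is not alone: compound 2 likewise carries no number. Only compound 3 yields a measured value. Compound 4 `CC[C@@H]1C(=O)N(C)c2cnc(-n3ccc4cc(C(=O)NC5CCCC5)ccc43)nc2N1C1CCCC1` keeps the core of compound 1 and differs from it in one place, (cyclopentylcarbamoyl in place of fluoro on an aromatic carbon). Within the data shown here, no measured pair that differs in one place exists to set the size of such a step, so the direction must be judged from the three compounds alone. Compound 2, which also carries a carbamoyl-type group on the same fused ring system, was not active, which tempers any expectation of a large gain in this assay. Compound 4 is expected to give about 3000 nM, within a range of 500 nM to 20000 nM.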

Compound 4, concentration for 50% growth inhibition: 795 nM
The estimate for compound 4 lay 3.8-fold (0.58 log units) above the measured number; the range from low to high includes it.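

Among these compounds, compound 1 has no number in this assay, and no step from it to compound 4 can be read. Nothing measured here offers an explanation for the value of compound 4. From the compounds shown here alone, how far cyclopentylcarbamoyl in place of fluoro shifts growth inhibition stays open.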